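Pyridylmethylamine series: solubility and the aryl group on the core

A few compounds are considered here, and "the series" means these few. Any claim that something is new, unique, unknown or untested is made for them only; others in the source may bear on it.

Of the compounds shown here, three of the shared core have been measured in a physicochemical assay for solubility, read by HPLC, using the shake flask method, measured as kinetic solubility, with a stated time of 2 h, at pH 7.4; a higher number here means a more soluble compound, a lower number a less soluble compound. Compound 1 `Cc1cc(N(C)Cc2ccccn2)n2nc(C)c(-c3ccccc3)c2n1` gives 17500 nM. Compound 2 `Cc1cc(NCc2nccs2)n2nc(C)c(-c3ccccc3)c2n1` gives 108000 nM. Compound 3 `Cc1cc(NCc2ccccn2)n2ncc(-c3cccc(F)c3)c2n1` gives 5000 nM, the lowest of the three numbers; the gap to compound 1 and the larger gap to compound 2 both lie beyond the scatter. Compound 4 `Cc1cc(NCc2ccccn2)n2ncc(-c3cncnc3)c2n1` has not yet been measured. It differs from compound 3 in one place: pyrimidin-5-yl in place of 3-fluorophenyl on an aromatic carbon. Going by the values given here, no measured pair in the set shows this change, so the size of the step is open. A rise beyond the scatter is expected, of about a 3.0-fold higher number from compound 3 to compound 4 (0.48 log units; beyond the scatter). For compound 4 the estimate is 15000 nM, with a range from 6000 nM to 45000 nM.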

Compound 4, solubility: 111000 nM
Beside the measured number, compound 4's estimate is 7.4-fold (0.87 log units) below it; the measured number lies above the stated range.
By their numbers in this assay, from the lowest: compound 3; then compound 1; then compounds 2 and 4 (each within the scatter of the next).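

Going by these compounds alone, on the aromatic carbon two ring bonds from the ring nitrogen, pyrimidin-5-yl in place of 3-fluorophenyl gives the first single-change step in this assay: a 22-fold higher number from compound 3 to compound 4 (1.35 log units; beyond the scatter). This position is therefore not silent: changing only the aromatic ring there moves the number widely. Nothing measured here bears on the reason for the step.

On these data alone, whether pyridin-3-yl at this position would land nearer compound 3 or compound 4 remains open. Also open, as far as these compounds go, is whether the step carries over to the amine side chains of compound 1 and compound 2.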